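Removing the alpha methyl on the acid chain of compound 1

A few compounds are considered here, and "the series" means these few. Any claim that something is new, unique, unknown or untested is made for them only; others in the source may bear on it.

Measured so far:
compound 1, `C[C@@H](C(=O)O)c1nn(Cc2cn3cc(OCC4CC4)c(Cl)cc3n2)c2ccccc2c1=O`, 253 nM
compound 2, `CCn1nc(CC(=O)Nc2ccc(OC(F)(F)F)c(Cl)c2)c2ccccc2c1=O`, 473 nM
compound 3, `CCOc1cc2[nH]c(Cc3nn(CC(=O)N4CCOCC4)c(=O)c4ccccc34)nc2cc1Cl`, 22 nM

All three numbers come from a functional assay on CHO cells for antagonist activity at sphingosine 1-phosphate receptor 2 (Homo sapiens), read by GTPgammaS binding; on this read-out higher numbers stand for weaker inhibition and lower numbers for stronger inhibition. Compound 1 gives the second highest of the three numbers. Its nearest neighbour is compound 2, which gives 473 nM, a gap that lies within the scatter, so the two cannot be put in order. Compound 3 stands apart with 22 nM, a gap beyond the scatter, so compound 3 inhibits more strongly than compound 1.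

Compound 4 is `O=C(O)Cc1nn(Cc2cn3cc(OCC4CC4)c(Cl)cc3n2)c2ccccc2c1=O`. It differs from compound 1 in one place:
hydrogen in place of methyl on a saturated chain carbon bound to an aromatic carbon and a carbonyl carbon
The same change, read one bond further out, is 1-carboxyethyl to carboxymethyl.

Among the compounds with values here, no measured pair shows this change, so its size can only be guessed. In this assay the step of a 1.2-fold lower number from compound 1 to compound 4 (0.06 log units; within the scatter) is expected to be small, within the scatter, in no sure direction. Compound 4 is therefore estimated at 220 nM, with a range from 70 nM to 700 nM.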

Compound 4, half-maximal inhibitory concentration: 30 nM
The estimate for compound 4 lay 7.3-fold (0.87 log units) above the measured number; the whole stated range lies above it.
By their numbers in this assay, from the lowest: compounds 3 and 4 (each within the scatter of the next); then compounds 1 and 2 (each within the scatter of the next).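

In this assay, within the data shown here, the change from 1-carboxyethyl to carboxymethyl gives an 8.4-fold lower number from compound 1 to compound 4 (0.93 log units; beyond the scatter), and this is the first pair that differs in only one place. It shows that this saturated chain carbon bound to an aromatic carbon and a carbonyl carbon is sensitive to substitution: the loss of one methyl, a single heavy atom, is enough to give stronger inhibition, with the rest of the structure unchanged. Nothing measured here accounts for the size of this step.

As far as these compounds go, it remains open whether an ethyl group, a fluorine atom or two methyl groups on this carbon would also give weaker inhibition than hydrogen, and how the opposite configuration of the methyl would compare. Among these compounds, with only one pair, it is also unknown whether the same step would hold on another core.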